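Swapping 4-bromophenyl for furan-2-yl on a carbonyl

A few compounds are considered here, and "the series" means these few. Any claim that something is new, unique, unknown or untested is made for them only; others in the source may bear on it.

In a functional assay on K562 cells (Homo sapiens) for cytotoxicity, read by MTT assay (on this read-out lower numbers stand for stronger inhibition and higher numbers for weaker inhibition), compound 1 `C#CCOc1cc(/C=C/C(=O)c2ccc(OC)c3c2OC(C)(C)C=C3)ccc1OC` gives only a limit, > 10000 nM. Compound 2 `COc1ccc(/C=C/C(=O)c2ccc(OC)c3c2OC(C)(C)C=C3)cc1OC(=O)CCl` gives 400 nM, and compound 3 `COc1ccc(/C=C/C(=O)c2ccc(OC)c3c2OC(C)(C)C=C3)cc1OC(=O)c1ccc(Br)cc1` gives 1110 nM, the higher of these two true numbers. Compound 4 `COc1ccc(/C=C/C(=O)c2ccc(OC)c3c2OC(C)(C)C=C3)cc1OC(=O)c1ccco1` has furan-2-yl in place of 4-bromophenyl on a carbonyl carbon. The closest guide is a 2.8-fold higher number from compound 2 to compound 3 (0.44 log units; beyond the scatter), a modest step from a change on that same carbonyl carbon. The larger steps, an at least 25-fold lower number from compound 1 to compound 2 (1.39 log units; beyond the scatter) and an at least 9.0-fold lower number from compound 1 to compound 3 (0.95 log units; beyond the scatter), replace propargyl, so they bear less directly on this swap. The expected change is small and downward, within the scatter: a 1.6-fold lower number from compound 3 to compound 4 (0.20 log units; within the scatter). The estimate for compound 4 is 700 nM, with an expected range of 250 nM to 2000 nM.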

Compound 4, half-maximal inhibitory concentration: 450 nM
The estimate for compound 4 lay 1.6-fold (0.19 log units) above the measured number, and the stated range covers the measured number.
By their numbers in this assay, from the lowest: compounds 2 and 4 (each within the scatter of the next); then compound 3. At a limit, above all of these: compound 1.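

On this carbonyl carbon, the choice of aromatic ring changes the result: a 2.5-fold lower number from compound 3 to compound 4 (0.39 log units; beyond the scatter). An aromatic ring here need not cost anything against chloromethyl, as the two values stay within the scatter: a 1.1-fold higher number from compound 2 to compound 4 (0.05 log units; within the scatter). A third group on this oxygen also improves on propargyl, an at least 22-fold lower number from compound 1 to compound 4 (1.34 log units; beyond the scatter), though that step is only a bound set by a limit: the limit of > 10000 nM in this assay, at which 1 of the 4 values shown sits.

Compounds 3 and 4 differ in ring size, ring oxygen and bromine at once, and the compounds shown do not separate these. Also open, on these data alone, is how a plain phenyl or a thiophene on this carbonyl carbon would read.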